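The compounds below may be only part of what the source reports. "The series", "measured", "known", "first", "only" and "open" are said of these compounds alone.

Measured so far:
compound 1, `OCC#CCSc1cnc2ccccc2c1Cl`: 2.4 ug/mL
compound 2, `CSc1cnc2ccccc2c1[Se]CC#CCOC(=O)/C=C/c1ccccc1`: 43.9 ug/mL

In a functional assay on P388 cells (Mus musculus) for antiproliferative activity, with a stated time of 72 h (a higher number here means a weaker inhibitor, a lower number a stronger inhibitor), compound 1 gives 2.4 ug/mL and compound 2 gives 43.9 ug/mL. Among the measured compounds shown here, compound 2 holds the higher of the two numbers, and its gap to compound 1 is beyond the scatter; the two compounds differ at several places at once, so no single step is known between them. Compound 3, `CSc1cnc2ccccc2c1[Se]CC#CCOC(=O)c1ccccc1`, is not yet measured. It differs from compound 2 in one place: phenyl in place of 2-phenylethenyl on a carbonyl carbon. For the measured compounds named here, no measured pair shows this change. The step of a 1.1-fold lower number from compound 2 to compound 3 (0.04 log units; within the scatter) is expected to stay within the scatter, with no clear direction. Compound 3 is therefore expected at 40 ug/mL, with a range from 15 ug/mL to 110 ug/mL.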

Compound 3, concentration for 50% inhibition: 3.5 ug/mL
The estimate for compound 3 lay 11-fold (1.06 log units) above the measured number, and the stated range ends above it.
By their numbers in this assay, from the lowest: compounds 1 and 3 (each within the scatter of the next); then compound 2.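

Among the compounds shown here, on the carbonyl carbon of this ester, the group carried matters: in this assay, phenyl in place of 2-phenylethenyl gives a 13-fold lower number from compound 2 to compound 3 (1.10 log units; beyond the scatter) and is the only single-place step so far. The change takes away the double bond outside aromatic rings and goes from 8 heavy atoms to 6, and these two differences cannot be separated here. Nothing available explains the size of the step. A 2-phenylethyl group on the same carbonyl carbon would separate the double bond from chain length. As far as these compounds go, whether an amide in place of the ester keeps the number of compound 3 remains open.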